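A few compounds are considered here, and "the series" means these few. Any claim that something is new, unique, unknown or untested is made for them only; others in the source may bear on it.

Working notes on the series.

Among the compounds with values here, compound 1 `O=c1cc(-c2ccccc2)oc2cc(OCCCCN3CCN(c4ccccc4)CC3)ccc12` is the first reference. In a functional assay for antagonist activity at Adrenergic receptor alpha-1 (Rattus norvegicus) (a lower number here means tighter binding, a higher number weaker binding), compound 1 gives 4.65 nM. Compound 2 `Cc1ccc(N2CCN(CCCCOc3ccc4c(=O)cc(-c5ccccc5)oc4c3)CC2)cc1` differs from compound 1 by one change, (methyl in place of hydrogen on an aromatic carbon), and in this assay compound 2 gives 195 nM. Within the data shown here, the step of a 42-fold higher number from compound 1 to compound 2 (1.62 log units; beyond the scatter) is the only measured instance of this change in the set, and it is a large one.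

Compound 3 `O=c1cc(-c2ccc(Cl)cc2)oc2cc(OCCCN3CCN(c4ccccc4)CC3)ccc12` carries a different core; how its core differs from that of compound 1 is not broken down here. In this assay compound 3 gives 8.47 nM, which lies within the usual scatter of the value of compound 1 and well away from that of compound 2.

Compound 4 `Cc1ccc(N2CCN(CCCOc3ccc4c(=O)cc(-c5ccc(Cl)cc5)oc4c3)CC2)cc1` has not yet been measured. It stands to compound 3 as compound 2 stands to compound 1: the change is methyl in place of hydrogen on an aromatic carbon, the same change as before, made at the same kind of place on the same kind of ring.

Expectation: since the only measured instance of this change, a 42-fold higher number from compound 1 to compound 2 (1.62 log units; beyond the scatter), was large, and since compound 3 starts close to where compound 1 started, the step from compound 3 to compound 4 is expected to be a 35-fold higher number from compound 3 to compound 4 (1.55 log units; beyond the scatter). This rests on a single pair, so the range is kept wide. In this assay compound 4 is estimated at 300 nM, with a range from 80 nM to 1200 nM.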

Compound 4, dissociation constant: 8.17 nM
Beside the measured number, compound 4's estimate is 37-fold (1.56 log units) above it, and the stated range ends above it.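

In this assay, the change from phenyl to 4-methylphenyl gives a 1.0-fold lower number from compound 3 to compound 4 (0.02 log units; within the scatter), and the two instances of this change do not agree: the same change on two cores in this assay, a 42-fold higher number (1.62 log units; beyond the scatter) from compound 1 to compound 2 and a 1.0-fold lower number (0.02 log units; within the scatter) from compound 3 to compound 4, 43-fold (1.64 log units) apart, beyond the scatter of two such steps

So in this series the size of the step depends on the core that carries it, and the large step seen on the core of compound 1 does not transfer to the core of compound 3. These two pairs do not show which of the differences between the two cores goes with the gap, and they give no basis for predicting the step on any further core.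

The compounds shown leave open whether a group other than methyl at the same place, such as methoxy or a carboxylic acid, would also give steps that differ between the two cores. They also leave open how the step would behave with a longer chain between the shared core and the piperazine-bearing end of the molecule, since the pairs shown do not separate the chain from the other differences between the cores.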